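Ortho-Fluorine on the Phenethyl Amide of Compound 1

The source may hold more compounds than are shown below. What is called first, only, known or untested is meant among the compounds shown, and "the series" means these compounds.

Compound 1 `O=C(CCc1ccccc1)Nc1nc2ccccc2c(=O)s1`: 390 nM
Compound 2 `O=C(COc1cccc(Cl)c1)Nc1nc2ccccc2c(=O)s1`: > 1000 nM
Compound 3 `O=C(C/C=C/c1ccccc1)Nc1nc2ccccc2c(=O)s1`: 158 nM

In an assay on CHO cells for displacement of a labelled ligand from adenosine receptor A3 (Homo sapiens), read by scintillation counting, with a stated time of 60 min (a lower number here means a stronger inhibitor, a higher number a weaker inhibitor), compound 1 gives 390 nM. Of the two compounds with a numbered value, compound 1 has the higher one; compound 3, with 158 nM, sits lower by a gap that is beyond the usual scatter. For compound 2 the assay reports only a limit, > 1000 nM, not a number. Compound 4 `O=C(CCc1ccccc1F)Nc1nc2ccccc2c(=O)s1` shares the core and the three-carbon amide of compound 1 and differs in one place: fluoro in place of hydrogen on an aromatic carbon. Within the data shown here, no measured pair here shows what such a change does, so in this assay a step of no more than the scatter is expected, in either direction. Compound 4 is therefore estimated at 350 nM, between 150 nM and 900 nM, a step of a 1.1-fold lower number from compound 1 to compound 4 (0.05 log units; within the scatter).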

Compound 4, inhibition constant: >= 1000 nM
Compound 4 gave a limit, no number; the forecaster's own chance of this, stated with the estimate: 10%; middle value at least 2.8-fold (0.45 log units) from the limit.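

In this assay, among these compounds, the change from phenyl to 2-fluorophenyl gives the first readable single-place step in this set, and it runs towards a weaker inhibitor: an at least 2.5-fold higher number from compound 1 to compound 4 (0.40 log units; beyond the scatter). Adding one fluorine atom to this ring carbon, ortho to a large group, is therefore enough to move the result beyond the scatter. As far as these compounds go, compound 4 has a limit, >= 1000 nM, not a number, so the full size of the step remains unknown. From the compounds shown here alone, what a methyl or methoxy group would do on this same carbon remains open, as does whether fluoro on another carbon of the ring would act alike.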